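Cytotoxicity working notes: nitro to methoxy step

A few compounds are considered here, and "the series" means these few. Any claim that something is new, unique, unknown or untested is made for them only; others in the source may bear on it.

Compound 1 `C/C(=C\c1cc(-c2ccc(C)cc2)cs1)C(N)=O` and compound 2 `C/C(=C\c1cc(-c2ccc([N+](=O)[O-])cc2)cs1)C(N)=O` share one core and differ in a single place, nitro in place of methyl on an aromatic carbon. In an ADME assay on NIH3T3 cells (Mus musculus) for cytotoxicity, read by CCK-8 assay, with a stated time of 24 h (on this read-out higher numbers stand for weaker inhibition and lower numbers for stronger inhibition), compound 1 gives > 50000 nM, which is a limit of the assay and not a number. In this assay compound 2 sits at > 50000 nM, again a limit. The step that the two limits leave unreadable from compound 1 to compound 2 therefore cannot be read in size or direction, since both values sit on (the limit of > 50000 nM in this assay, at which 2 of the 2 values shown sit). Compound 2 thus stands only at a limit, with no number on the scale. Compound 3 `COc1ccc(-c2csc(/C=C(\C)C(N)=O)c2)cc1` follows from compound 2 by methoxy in place of nitro on an aromatic carbon. Among the measured compounds shown here, the one measured step bears on this change but is itself unreadable, so no size can be carried over; for this change the expected step in this assay is a step that the limit leaves unreadable from compound 2 to compound 3, none beyond the scatter. Compound 3 is accordingly estimated at 60000 nM, with a range from 20000 nM to 200000 nM, most likely reported once more as a limit.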

Compound 3, half-maximal inhibitory concentration: > 50000 nM
Compound 3: only a limit was reported; the forecaster's own chance of this, stated with the estimate: 85%; the middle value does not contradict the limit.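

No new step can be read among compound 1, compound 2 and compound 3 in this assay, since each value is a limit and not a number: the limit of > 50000 nM in this assay, at which 3 of the 3 values shown sit.

The compounds shown leave open whether any group in this place on the shared core gives a number on the scale, and how methyl, nitro and methoxy would compare.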